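The source may report more compounds than this note shows. Statements on the series, on what has been measured and on what is new or still open speak of the compounds shown alone.

Of the compounds shown here, three built on one shared core have been tested in a functional assay on HeLa cells (Homo sapiens) for antiproliferative activity, read by MTT assay, with a stated time of 72 h; a lower number here means a stronger inhibitor, a higher number a weaker inhibitor. Compound 1 `O=C(Nc1ccc(Cl)c(-c2nnc3c(Cl)cccn23)c1)c1ccc(C(F)(F)F)cc1F` gives 61900 nM. Compound 2 `CS(=O)(=O)c1ccc(C(=O)Nc2ccc(Cl)c(-c3nnc4c(Cl)cccn34)c2)c(Cl)c1` reaches only a limit of the assay, > 100000 nM. Compound 3 `O=C(Nc1ccc(Cl)c(-c2nnc3c(Cl)cccn23)c1)c1c(F)cccc1Cl` likewise reaches only a limit of the assay, > 100000 nM. Compound 3 therefore stands at the limit of > 100000 nM in this assay, at which 2 of the 3 values shown sit, so no number of its own is known for it, and on this scale all three compounds are weak inhibitors. Compound 4 `O=C(Nc1ccc(Cl)c(-c2nnc3c(Cl)cccn23)c1)c1ccc(Cl)cc1Cl` has not yet been measured in this assay. It differs from compound 3 in one place: 2,4-dichlorophenyl in place of 2-chloro-6-fluorophenyl on a carbonyl carbon. No measured pair among these compounds differs by a change of this kind, so the expected step is small and within the usual scatter, with no clear direction. The value of compound 4 is estimated at 90000 nM, within a range of 30000 nM to 300000 nM, which corresponds to an expected step of an at least 1.1-fold lower number from compound 3 to compound 4 (0.04 log units; that floor lies within the scatter), and a result that again shows only a limit is expected to be quite possible.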

Compound 4, half-maximal inhibitory concentration: > 100000 nM
Compound 4 gave a limit, no number (the forecaster's own chance of this, stated with the estimate: 55%); middle value at least 1.1-fold (0.04 log units) away from the limit.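

Compound 4 gives only a limit of the assay, > 100000 nM, and compound 2 and compound 3 also give only limits, so neither step to compound 4 can be read. What stays open is whether 2,4-dichlorophenyl and 2-chloro-6-fluorophenyl differ in activity at all, because these compounds give no number on either side: the limit of > 100000 nM in this assay, at which 3 of the 4 values shown sit.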